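From methoxy to benzyloxycarbonyl in the antiproliferative series

The compounds below may be only part of what the source reports. "The series", "measured", "known", "first", "only" and "open" are said of these compounds alone.

In a functional assay on HeLa cells (Homo sapiens) for antiproliferative activity, read by MTT assay, with a stated time of 48 h (a higher number here means a weaker inhibitor, a lower number a stronger inhibitor), compound 1 (`O=C(OCc1ccccc1)c1ccc2[nH]c(-c3cn(-c4ccccc4)nc3-c3ccccc3)nc2c1`) gives 21300 nM and compound 2 (`COc1ccc2[nH]c(-c3cn(-c4ccccc4)nc3-c3ccc(Cl)cc3)nc2c1`) gives 3630 nM as the lower of the two numbers, with a gap beyond the scatter. Compound 3 (`O=C(OCc1ccccc1)c1ccc2[nH]c(-c3cn(-c4ccccc4)nc3-c3ccc(Cl)cc3)nc2c1`) is still unmeasured and differs from compound 2 by benzyloxycarbonyl in place of methoxy on an aromatic carbon. For the measured compounds named here, no measured pair shows this change alone, so its size in this assay cannot be read directly. Going by the values given here, the only guide is compound 1, which also carries benzyloxycarbonyl and stands at 21300 nM on the higher side of the pair. The estimated 2.5-fold higher number from compound 2 to compound 3 (0.39 log units; beyond the scatter) is therefore an upward one, toward weaker inhibition. It is expected to be moderate, probably beyond the scatter, and smaller than the whole gap between the two measured compounds, since that gap need not belong to this change alone. Compound 3 is expected at 9000 nM within a range from 3000 nM to 27000 nM as a working figure.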

Compound 3, half-maximal inhibitory concentration: 8130 nM
Estimate against measurement, compound 3: 1.1-fold (0.04 log units) above; low and high end bracket the measured number.
By their numbers in this assay, from the lowest: compound 2; then compound 3; then compound 1.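

Read alone in this assay, the change from methoxy to benzyloxycarbonyl on this aromatic carbon appears as a 2.2-fold higher number from compound 2 to compound 3 (0.35 log units; beyond the scatter). This is therefore a modest loss rather than the whole gap between compound 1 and compound 2. With benzyloxycarbonyl held fixed, chloro in place of hydrogen on an aromatic carbon appears as a 2.6-fold lower number from compound 1 to compound 3 (0.42 log units; beyond the scatter) and separates a second contribution, so that gap is not the work of one change alone. This position, para or meta to a fused ring as the structure reads, carries benzyloxycarbonyl with its additional six-membered aromatic ring at only a modest cost, although compound 2 remains the lowest of the three numbers.

Still open, from the compounds shown here alone, is which part of benzyloxycarbonyl goes with the step, a question that a carboxylic acid, a methyl ester or an amide at the same carbon would address, and whether the chloro step holds with methoxy in place, since it is read here only on the benzyloxycarbonyl compounds. Nothing in hand gives a reason for either step.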